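Carrying a Benzyl Swap from a Limit into the Unknown

A few compounds are considered here, and "the series" means these few. Any claim that something is new, unique, unknown or untested is made for them only; others in the source may bear on it.

Measured compounds:
compound 1, `COC(=O)[C@H](CCSC)NC(=O)c1ccc(CNCc2c[nH]cn2)cc1-c1ccccc1C`: 25 uM
compound 2, `CSCC[C@H](NC(=O)c1ccc(NCc2cncn2Cc2ccccc2C#N)cc1-c1ccccc1)C(=O)O`: > 10 uM
compound 3, `COC(=O)[C@H](CCSC)NC(=O)c1ccc(NCc2cncn2Cc2ccccc2C#N)cc1-c1ccccc1`: > 10 uM

In a functional assay on NIH3T3 cells (Mus musculus) (a lower number here means that less compound is needed, a higher number that more compound is needed for the effect), compound 1 gives 25 uM. Compound 2 sits at > 10 uM, which is a limit of this assay and not a number. Compound 3 likewise reaches only a limit, > 10 uM. Among the compounds with values here, the one measured step, a step that the two limits leave unreadable from compound 2 to compound 3, is therefore unreadable, and the limit of > 10 uM in this assay, at which 2 of the 3 values shown sit, is where two of the three values rest.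

The new compound 4, `CSCC[C@H](NC(=O)c1ccc(NCc2cncn2Cc2ccc(Cl)cc2)cc1-c1ccccc1)C(=O)O`, differs from compound 2 by 4-chlorophenyl in place of 2-cyanophenyl on a saturated chain carbon bound to an aromatic nitrogen. Within the data shown here, no measured step touches the benzyl portion, so nothing here predicts the direction of this change, and compound 2 itself offers only a limit as the starting point. The most the numbers support is that compound 4 is expected to land near that limit as well, so the step that the limit leaves unreadable from compound 2 to compound 4 is estimated to stay small and of unknown sign. Compound 4 is accordingly expected at about 20 uM, with a range from 5 uM to 80 uM, and the assay may well report only a limit again.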

Compound 4, concentration for half-maximal effect: > 10 uM
Compound 4 ended at the assay's limit; the forecaster's own chance of this, stated with the estimate: 65%; the middle value does not contradict the limit.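

In this assay compound 4 reaches > 10 uM as a limit and not a number. Within the data shown here, compound 2 also rests on a limit, so no step from compound 2 to compound 4 can be read. The compounds shown leave open how 2-cyanobenzyl and 4-chlorobenzyl truly compare.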